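A few compounds are considered here, and "the series" means these few. Any claim that something is new, unique, unknown or untested is made for them only; others in the source may bear on it.

In an in vitro ADME assay on microsomes from liver (Mus musculus) for pharmacokinetics (a higher number here means faster removal of the compound, a lower number slower removal), compound 3 `CC(C)C1CCNC(=O)C(N(Cc2ccc(C(=O)NC3CC3)cc2)S(=O)(=O)c2ccc(Cl)cc2)C1` gives 203 mL.min-1.g-1 and compound 1 `CC(C)(C)C1CCNC(=O)C(N(Cc2ccc(C(=O)NC3CC3)cc2)S(=O)(=O)c2ccc(Cl)cc2)C1` gives 110 mL.min-1.g-1, two values within the scatter of each other, while compound 2 `CC1(C)CCNC(=O)[C@H](N(Cc2ccc(C(=O)NC3CC3)cc2)S(=O)(=O)c2ccc(Cl)cc2)C1` stands highest of the three at 655 mL.min-1.g-1. The step to compound 4 `CC1(C)CCNC(=O)C(N(Cc2ccc(C(=O)NC3CC3)cc2)S(=O)(=O)c2ccc(Cl)cc2)C1` is 5,5-dimethyl-2-oxoazepan-3-yl in place of 5-isopropyl-2-oxoazepan-3-yl on a sulfonamide nitrogen. Compound 2 carries the same group, with one configuration defined. The reverse change is measured as a 3.2-fold lower number from compound 2 to compound 3 (0.51 log units; beyond the scatter), and a 6.0-fold higher number from compound 1 to compound 2 (0.77 log units; beyond the scatter) points the same way. A rise of similar size is therefore expected, a 2.7-fold higher number from compound 3 to compound 4 (0.43 log units; beyond the scatter). Compound 4 is estimated at 550 mL.min-1.g-1, with an expected range of 300 mL.min-1.g-1 to 950 mL.min-1.g-1.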

Compound 4, intrinsic clearance in microsomes: 191 mL.min-1.g-1
Compound 4: middle estimate off by 2.9-fold (0.46 log units), on the high side, and the stated range ends above it.
By their numbers in this assay, from the lowest: compounds 1, 4 and 3 (each within the scatter of the next); then compound 2.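

In this assay, 5,5-dimethyl-2-oxoazepan-3-yl and 5-isopropyl-2-oxoazepan-3-yl on the sulfonamide nitrogen cannot be told apart, with a 1.1-fold lower number from compound 3 to compound 4 (0.03 log units; within the scatter), and the same holds for 2-oxo-5-(tert-butyl)azepan-3-yl, with a 1.7-fold higher number from compound 1 to compound 4 (0.24 log units; within the scatter). The high number therefore stands with compound 2 alone, with a 3.4-fold lower number from compound 2 to compound 4 (0.54 log units; beyond the scatter). This gap, beyond the scatter, comes without any change in atoms or bonds, and the one difference is: the fact that one of compounds 2 and 4 is drawn with a defined configuration and the other without, at the place where they differ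

Going by these compounds, whether compound 4 holds both configurations, and what the other configuration alone would give, remains open. Also open, on these data alone, is how an amine or a carboxylic acid would read at this place.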